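Swapping the furan-2-yl carbonyl amino group of compound 3

The source may report more compounds than this note shows. Statements on the series, on what has been measured and on what is new or still open speak of the compounds shown alone.

Compound 1 `CCOc1cc(=O)n(CCCO)c2c1CC(CC=C(C)C)C(C)(C)C2`: 7300 nM
Compound 2 `CC(C)=CCC1Cc2c(OC(=O)Nc3ccc(F)c(F)c3)cc(=O)n(CCCO)c2CC1(C)C`: 7300 nM
Compound 3 `CC(C)=CCC/C(C)=C/CC1Cc2c(OCCCNC(=O)c3ccco3)cc(=O)n(CCCO)c2CC1(C)C`: 5200 nM

In a functional assay on PANC-1 cells (Homo sapiens) for inhibition, read by MTT assay, with a stated time of 24 h (on this read-out higher numbers stand for weaker inhibition and lower numbers for stronger inhibition), compound 3 gives 5200 nM. This number lies within the usual scatter of those of compound 1 and compound 2, so the three values cannot be ranked.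

Compound 4 `CC(C)=CCC/C(C)=C/CC1Cc2c(OCCCOc3ccc([N+](=O)[O-])cc3)cc(=O)n(CCCO)c2CC1(C)C`, not yet measured, differs from compound 3 by one change: 4-nitrophenoxy in place of ((furan-2-yl)carbonyl)amino on a saturated chain carbon, three bonds along the chain from an oxygen on an aromatic ring. It thus carries 4-nitrophenoxy in place of ((furan-2-yl)carbonyl)amino on a saturated chain carbon, three bonds along the chain from an oxygen on an aromatic ring.

Within the data shown here, only one measured step offers any guide: no change at the digits printed from compound 1 to compound 2 (within the scatter), with (3,4-difluorophenyl)carbamoyl in place of ethyl on an oxygen on an aromatic ring. It does not involve either group in the present swap, so its support is indirect.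

The expected step in this assay is a 1.1-fold higher number from compound 3 to compound 4 (0.02 log units; within the scatter), with no direction expected beyond the scatter. The estimate for compound 4 is 5500 nM, with an expected range of 2200 nM to 13000 nM.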

Compound 4, half-maximal inhibitory concentration: 6300 nM
The estimate for compound 4 lay 1.1-fold (0.06 log units) below the measured number, within the range that was stated.
By their numbers in this assay, from the lowest: compounds 3, 4, 1 and 2 (each within the scatter of the next).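

Among these compounds, the first step at this chain position, a 1.2-fold higher number from compound 3 to compound 4 (0.08 log units; within the scatter), shows that in this assay the end of the three-carbon chain on the ring oxygen accepts a marked change of group without a shift beyond the scatter. The exchange replaces the five-membered aromatic ring with a six-membered ring of carbon only, removes the amide hydrogen, and brings in a nitro group, yet compound 3 and compound 4 cannot be told apart on this read-out. No measurement among the data speaks to why the value stays within the scatter.

The compounds shown leave open whether this position would respond to a group of another kind, such as a primary amine or a carboxylic acid at the end of the chain. They also leave open whether a shorter or longer chain would change the number.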